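Chalcone lactam series: 3-nitrophenyl for 2-methoxyphenyl

A few compounds are considered here, and "the series" means these few. Any claim that something is new, unique, unknown or untested is made for them only; others in the source may bear on it.

Compound 1 has the structure `COc1ccccc1/C=C/C(=O)c1ccc(OCC(=O)N[C@H]2CCOC2=O)cc1` and is the reference for this step. In a functional assay on MCF7 cells (Homo sapiens) for antiproliferative activity, read by MTT assay, with a stated time of 72 h (a higher number here means a weaker inhibitor, a lower number a stronger inhibitor), compound 1 gives > 64000 nM, which is a limit of the assay and not a number. Among the compounds with values here, compound 2, `O=C(CNc1ccc(Cl)cc1Cl)N[C@H]1CCOC1=O`, is the only other member with a result so far. In this assay compound 2 gives > 64000 nM, again a limit rather than a number. Where compound 1 stands is therefore fixed only by the limit of > 64000 nM in this assay, at which 2 of the 2 values shown sit; nothing measured separates it from compound 2, and no step between measured compounds is available in this assay.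

Compound 3, `O=C(COc1ccc(C(=O)/C=C/c2cccc([N+](=O)[O-])c2)cc1)N[C@H]1CCOC1=O`, is the next member to be run in this assay. It differs from compound 1 by 3-nitrophenyl in place of 2-methoxyphenyl on a double-bonded chain carbon bound to a double-bonded chain carbon. With both measured values sitting at the limit, no direction can be read from the data, and the expected step from compound 1 to compound 3 is a step that the limit leaves unreadable from compound 1 to compound 3, which is taken as none beyond the scatter. Compound 3 is accordingly estimated at 70000 nM in this assay, within 20000 nM to 250000 nM, with a real chance that only a limit is returned again.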

Compound 3, half-maximal inhibitory concentration: > 64000 nM
Compound 3: a limit, no number (the forecaster's own chance of this, stated with the estimate: 70%); the middle value does not contradict the limit.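

In this assay compound 3 gives > 64000 nM, a limit of the assay and not a number. No step can be read between compound 1 and compound 3, as both rest on the same limit: the limit of > 64000 nM in this assay, at which 3 of the 3 values shown sit.

The compounds shown leave open whether any change on the shared core gives a numerical value in this assay, and how 3-nitrophenyl and 2-methoxyphenyl compare.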